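Removing a tert-butoxycarbonyl Group: Expected Effect on Splenocyte Toxicity

The source may hold more compounds than are shown below. What is called first, only, known or untested is meant among the compounds shown, and "the series" means these compounds.

Measured compounds:
Compound 1 `COc1ccc(-c2nc(Cc3c[nH]c4ccccc34)no2)c(OC)c1` gives 9300 nM in an ADME assay on cells (Splenocyte, Mus musculus, strain BALB/c) for cytotoxicity, read by CCK-8 assay, with a stated time of 48 h; on this read-out higher numbers stand for lower toxicity in this test and lower numbers for higher toxicity in this test.
Compound 2 `COc1cc(-c2noc(C34CCC(NC(=O)OC(C)(C)C)(CC3)CC4)n2)cc(OC)c1OC` gives 12700 nM in this assay.

Going by the values given here, only two compounds have been measured so far, and neither stands apart from the other. In this assay compound 2 gives the higher of the two numbers, but its gap to compound 1 lies within the usual scatter of this kind of measurement, so the two values should be read as equivalent rather than ordered. Compounds 1 and 2 also differ in several places at once, so nothing can be said about what any single change does here.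

The next compound, compound 3 `COc1cc(-c2noc(C34CCC(N)(CC3)CC4)n2)cc(OC)c1OC`, differs from compound 2 in one place: hydrogen in place of tert-butoxycarbonyl on an amine nitrogen. Among the compounds with values here, no measured pair in this set shows such a change, so there is no direct guide to its size or direction.

With nothing to point toward a larger effect, the step of a 1.4-fold lower number from compound 2 to compound 3 (0.15 log units; within the scatter) is expected to be small, most likely within the scatter. Compound 3 is therefore expected to give about 9000 nM, with a plausible range from 3500 nM to 25000 nM.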

Compound 3, half-maximal cytotoxic concentration: 25800 nM
Compound 3: the middle estimate sits 2.9-fold (0.46 log units) below what was measured, and the stated range ends below it.
By their numbers in this assay, from the lowest: compounds 1 and 2 (each within the scatter of the next); then compound 3.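

In this assay, going by these compounds alone, exchanging tert-butoxycarbonyl for hydrogen on this amine nitrogen gives a 2.0-fold higher number from compound 2 to compound 3 (0.31 log units; beyond the scatter), the first change in this set that can be read on its own. The earlier compounds shown here could not show this, as compound 1 and compound 2 differ in several places at once and their values sit within the scatter of each other. The new step shows that this position is not indifferent to what sits on the nitrogen: freeing the amino group moves the read-out toward lower toxicity in this test, by a modest step just beyond the usual scatter, though nothing available here accounts for the shift.

From the compounds shown here alone, it remains open whether the full tert-butoxycarbonyl group matters or only part of it, and an acetyl or a methyl group on the same nitrogen would help to show whether such compounds give numbers nearer to compound 2 or to compound 3. Going by these compounds, this is also a single pair on a single core, so whether the same exchange has a similar effect on a different core remains unknown.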